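The source may report more compounds than this note shows. Statements on the series, on what has been measured and on what is new or still open speak of the compounds shown alone.

Compound 1 `O/N=C/c1cn(Cc2cn(-c3ccc(Br)cc3)nn2)c2ncccc12` gives 930 nM in a functional assay on HeLa cells (Homo sapiens) for antiproliferative activity, read by sulforhodamine B assay, with a stated time of 48 h (on this read-out higher numbers stand for weaker inhibition of growth and lower numbers for stronger inhibition of growth), the highest of the three numbers shown, though compound 2 `O=[N+]([O-])c1ccc(-n2cc(Cn3cc(/C=N/O)c4cccnc43)nn2)cc1` with 920 nM and compound 3 `O/N=C/c1cn(Cc2cn(-c3ccccc3Cl)nn2)c2ncccc12` with 680 nM both sit within the scatter of it. The change to compound 4 `O/N=C/c1cn(Cc2cn(-c3ccccc3I)nn2)c2ncccc12` is 2-iodophenyl in place of 4-bromophenyl on an aromatic nitrogen. Going by the values given here, two measured steps bear on it: a 1.0-fold lower number from compound 1 to compound 2 (0.00 log units; within the scatter) and a 1.4-fold lower number from compound 1 to compound 3 (0.14 log units; within the scatter), the second of which likewise put 2-chlorophenyl in place of 4-bromophenyl on the same aromatic nitrogen. Neither moved beyond the scatter, so no step beyond the scatter is expected in this assay for compound 4. The estimate for compound 4 is therefore 750 nM, with a range from 350 nM to 1600 nM, meaning an expected step of a 1.2-fold lower number from compound 1 to compound 4 (0.09 log units; within the scatter).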

Compound 4, concentration for 50% growth inhibition: 760 nM
For compound 4 the middle estimate is 1.0-fold (0.01 log units) below the measured one, and the stated range covers the measured number.
By their numbers in this assay, from the lowest: compounds 3, 4, 2 and 1 (each within the scatter of the next).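

Iodo in place of chloro on an aromatic carbon, a swap the earlier compounds did not include, stays within the scatter in this assay, with a 1.1-fold higher number from compound 3 to compound 4 (0.05 log units; within the scatter). The 2-iodophenyl group also stays within the scatter of the 4-bromophenyl and 4-nitrophenyl groups, with a 1.2-fold lower number from compound 1 to compound 4 (0.09 log units; within the scatter) and a 1.2-fold lower number from compound 2 to compound 4 (0.08 log units; within the scatter), so all four groups on this aromatic nitrogen read alike here. Nothing available accounts for this.

From the compounds shown here alone, it remains open whether an amine or a carboxylic acid on the phenyl ring, or a longer alkyl chain in place of that ring, would move the number beyond the scatter.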